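Cytotoxicity in a bicyclic sulfonate nucleoside series

The source may report more compounds than this note shows. Statements on the series, on what has been measured and on what is new or still open speak of the compounds shown alone.

Compound 1 `CC#CC1=C(N)[C@@]2(OS1(=O)=O)[C@@H](CO[Si](C)(C)C(C)(C)C)O[C@@H](n1cc(C)c(=O)n(C)c1=O)[C@@H]2O[Si](C)(C)C(C)(C)C` is the reference point of the series. Its read-out is a functional assay on MT4 cells (Homo sapiens) for cytotoxicity (on this read-out lower numbers stand for higher toxicity in this test and higher numbers for lower toxicity in this test), where compound 1 gives 3300 nM. Of the two plain numbers shown, this is the lower one; the nearest is compound 3 `C=CCNC1=CS(=O)(=O)O[C@@]12[C@@H](CO[Si](C)(C)C(C)(C)C)O[C@@H](n1cc(C)c(=O)n(C)c1=O)[C@@H]2O[Si](C)(C)C(C)(C)C`, which in this assay gives 25000 nM, a gap beyond the usual scatter. Compound 2 `CNC1=C(C)S(=O)(=O)O[C@@]12[C@@H](CO[Si](C)(C)C(C)(C)C)O[C@@H](n1cc(C)c(=O)n(C)c1=O)[C@@H]2O[Si](C)(C)C(C)(C)C` reaches only a limit of the test: in this assay compound 2 gives > 250000 nM, which is the limit of > 250000 nM in this assay, at which 1 of the 3 values shown sits, so for compound 2 no number is known.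

Compound 4 `Cc1cn([C@@H]2O[C@H](CO[Si](C)(C)C(C)(C)C)[C@@]3(OS(=O)(=O)C(I)=C3N)[C@H]2O[Si](C)(C)C(C)(C)C)c(=O)n(C)c1=O` has not yet been measured. Relative to compound 1 the change is iodo in place of prop-1-yn-1-yl on a double-bonded ring carbon: iodo enters, prop-1-yn-1-yl leaves, on the double-bonded ring carbon of the five-membered non-aromatic ring.

No step between measured compounds is shown for this kind of change, so the expectation rests on compound 1 alone. The step from compound 1 to compound 4 is expected to go toward a higher number, with a size near the edge of the scatter, a 2.4-fold higher number from compound 1 to compound 4 (0.38 log units; beyond the scatter). For compound 4 in this assay the estimate is 8000 nM, with a likely range from 2500 nM to 40000 nM.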

Compound 4, half-maximal cytotoxic concentration: 3900 nM
Beside the measured number, compound 4's estimate is 2.1-fold (0.31 log units) above it, and the stated range covers the measured number.
By their numbers in this assay, from the lowest: compounds 1 and 4 (each within the scatter of the next); then compound 3. At a limit, above all of these: compound 2.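

In this assay, iodo in place of prop-1-yn-1-yl on the double-bonded ring carbon next to the ring sulfur gives a 1.2-fold higher number from compound 1 to compound 4 (0.07 log units; within the scatter). For the compounds shown here, this is the first reading at this position, and it shows that the triple bond of the prop-1-yn-1-yl group is not needed for the read-out of compound 1, since a single iodine atom there leaves the step within the scatter. Nothing measured here accounts for this outcome, and no cause can be assigned.

Compounds 1 and 4 are the only pair shown that differ in one place, so a single step describes this position. From the compounds shown here alone, whether an amine, a carboxylic acid or a longer alkyl chain on this carbon would also stay within the scatter of compound 1 remains open.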